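Series notes: carboxyalkyl variation on the shared core

The source may hold more compounds than are shown below. What is called first, only, known or untested is meant among the compounds shown, and "the series" means these compounds.

Compound 3 `CCC(C(=O)O)c1nn(Cc2cn3cc(OCC4CC4)c(Cl)cc3n2)c2ccccc2c1=O` gives 2.71 in a physicochemical assay for lipophilicity, at pH 7.4; on this read-out lower numbers stand for lower lipophilicity and higher numbers for higher lipophilicity. Of the three compounds measured it holds the second highest number. Going by the values given here, compound 1 `C[C@@H](C(=O)O)c1nn(Cc2cn3cc(OCC4CC4)c(Cl)cc3n2)c2ccccc2c1=O` gives 2.41 in this assay, and the only single-point step recorded, a number 0.30 log units higher from compound 1 to compound 3 (within the scatter), lies within the scatter. Compound 2 `COc1cc(OC)c(NC(=O)Cc2cn(C)c3ccccc23)cc1Cl`, on a different core, gives 5.91, far above the other two.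

Compound 4 `O=C(O)C1(c2nn(Cc3cn4cc(OCC5CC5)c(Cl)cc4n3)c3ccccc3c2=O)CC1` differs from compound 3 in one place: 1-carboxycyclopropyl in place of 1-carboxypropyl on an aromatic carbon. Among the compounds with values here, the measured step of a number 0.30 log units higher from compound 1 to compound 3 (within the scatter) concerns a chain grown by one carbon and is only a weak guide to the ring-forming change here; no measured pair shows such a change. With the heavy-atom count unchanged, compound 4 is expected to stay close, estimated at 2.5 with a range from 2.1 to 2.9. The expected step of a number 0.21 log units lower from compound 3 to compound 4 (within the scatter) lies within the scatter.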

Compound 4, distribution coefficient: 2.46
Estimate against measurement, compound 4: 0.04 log units above; measured number inside the range.
By their numbers in this assay, from the lowest: compounds 1, 4 and 3 (each within the scatter of the next); then compound 2.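

Forming the three-membered ring of carbon at this position, with the heavy-atom count unchanged, gives a step within the scatter (a number 0.25 log units lower from compound 3 to compound 4 (within the scatter)). The comparison with the shorter chain also stays within the scatter (a number 0.05 log units higher from compound 1 to compound 4 (within the scatter)), so 1-carboxyethyl, 1-carboxypropyl and 1-carboxycyclopropyl cannot be told apart in this assay. Nothing at hand offers an explanation for how closely these numbers sit.

Open, on these data alone, is whether a larger ring, such as 1-carboxycyclobutyl, would give a step beyond the scatter. Also open, as far as these compounds go, is what an amide or a tetrazole in place of the carboxylic acid would do at this position.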